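Swapping Methyl for Fluoro on the Sulfonyl Ring

This account rests on a few compounds, and the source may have more. Where it says the series, first, only, none or still open, it means among the compounds named here.

Measured so far:
compound 1, `Cc1ccc(S(=O)(=O)NC(=O)/C=C/c2ccc(F)cc2)cc1`: 4.8 ug/mL
compound 2, `O=C(/C=C/c1ccc(F)cc1)NS(=O)(=O)c1ccc(F)cc1`: 0.8 ug/mL
compound 3, `COc1ccc(/C=C/C(=O)NS(=O)(=O)c2ccc(C)cc2)cc1`: 12.2 ug/mL

These three compounds were tested in a functional assay on B16-F10 cells (Mus musculus) for antiproliferative activity, read by ELISA and MTT assay, with a stated time of 48 h; on this read-out lower numbers stand for stronger inhibition and higher numbers for weaker inhibition. Compound 1 and compound 2 differ by fluoro in place of methyl on an aromatic carbon; this change gave a 6.0-fold lower number from compound 1 to compound 2 (0.78 log units; beyond the scatter). Compound 3 differs from compound 1 by methoxy in place of fluoro on an aromatic carbon, which gave a 2.5-fold higher number from compound 1 to compound 3 (0.41 log units; beyond the scatter), so compound 3 has the highest number of the three.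

Compound 4, `COc1ccc(/C=C/C(=O)NS(=O)(=O)c2ccc(F)cc2)cc1`, has not yet been measured. It differs from compound 3 by fluoro in place of methyl on an aromatic carbon, the same change seen from compound 1 to compound 2, at a place described in identical words. If that change carries over, compound 4 is expected to show a step of a 5.1-fold lower number from compound 3 to compound 4 (0.71 log units; beyond the scatter) in this assay, resting on the size of a 6.0-fold lower number from compound 1 to compound 2 (0.78 log units; beyond the scatter). Going by the values given here, with only one earlier instance to lean on, the expected value for compound 4 is 2.4 ug/mL, with an estimated range from 0.9 ug/mL to 7 ug/mL.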

Compound 4, half-maximal inhibitory concentration: 5.1 ug/mL
For compound 4 the middle estimate is 2.1-fold (0.33 log units) below the measured one; measured number inside the range.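

Fluoro in place of methyl lowers the number again on a second core, with a 2.4-fold lower number from compound 3 to compound 4 (0.38 log units; beyond the scatter), and the size of this step agrees with the earlier one: the same change on two cores in this assay, a 6.0-fold lower number (0.78 log units; beyond the scatter) from compound 1 to compound 2 and a 2.4-fold lower number (0.38 log units; beyond the scatter) from compound 3 to compound 4, 2.5-fold (0.40 log units) apart, within the scatter of two such steps. Methoxy in place of fluoro likewise keeps its direction, with a 6.4-fold higher number from compound 2 to compound 4 (0.80 log units; beyond the scatter), and its two steps also agree: the same change on two cores in this assay, a 2.5-fold higher number (0.41 log units; beyond the scatter) from compound 1 to compound 3 and a 6.4-fold higher number (0.80 log units; beyond the scatter) from compound 2 to compound 4, 2.5-fold (0.40 log units) apart, within the scatter of two such steps. Going by these compounds alone, with only two pairs for each change in this assay, this shows a shared direction on these two cores, but it does not fix an exact step size or show that either change would carry over to any other core.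

On these data alone, it remains open how a chloro group or a nitrile would compare with methyl and fluoro in the same place. It is also unknown how an amine or a carboxylic acid would compare with methoxy and fluoro on the other ring.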